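Stereoisomer of the fluoromethylethyl carbamate in the shared series

This account rests on a few compounds, and the source may have more. Where it says the series, first, only, none or still open, it means among the compounds named here.

In a functional assay on isolated protein for agonist activity at Glucose-dependent insulinotropic receptor (Homo sapiens), read by HTRF and cAMP accumulation (on this read-out lower numbers stand for an effect already at smaller amounts and higher numbers for an effect only at larger amounts of compound), compound 1 `CC(C)(C)OC(=O)N1CCC(O[C@H]2CC[C@H](Oc3cnc(S(C)(=O)=O)cn3)CC2)CC1` gives 5.9 nM, compound 2 `CC(C)OC(=O)N1CCC(O[C@H]2CC[C@H](Oc3cnc(S(C)(=O)=O)cn3)CC2)CC1` gives 13.7 nM and compound 3 `C[C@H](CF)OC(=O)N1CCC(O[C@H]2CC[C@H](Oc3cnc(S(C)(=O)=O)cn3)CC2)CC1` gives 36.8 nM, the highest of the three numbers; the spread is carried by a 2.3-fold higher number from compound 1 to compound 2 (0.37 log units; beyond the scatter), a 6.2-fold higher number from compound 1 to compound 3 (0.79 log units; beyond the scatter) and a 2.7-fold higher number from compound 2 to compound 3 (0.43 log units; beyond the scatter). Compound 4 `C[C@@H](CF)OC(=O)N1CCC(O[C@H]2CC[C@H](Oc3cnc(S(C)(=O)=O)cn3)CC2)CC1` differs from compound 3 only in configuration: the two compounds have the same atoms and bonds and differ only in configuration as drawn: 2 of 3 stereo elements differ; a stereocentre at a saturated chain carbon is drawn R in compound 3 and S in compound 4; a stereocentre at a saturated ring carbon is drawn R in compound 3 and S in compound 4. Among the compounds with values here, none of the measured steps changes configuration alone; all three exchange groups on the oxygen next to the carbonyl, so they do not bear directly on this step. With no measured guide, the expected step in this assay from compound 3 to compound 4 is a 1.2-fold lower number from compound 3 to compound 4 (0.09 log units; within the scatter), in either direction within the scatter. Compound 4 is therefore estimated at 30 nM, range 10 nM to 100 nM.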

Compound 4, half-maximal effective concentration: 31.1 nM
Compound 4: middle estimate off by 1.0-fold (0.02 log units), on the low side, within the range that was stated.
By their numbers in this assay, from the lowest: compound 1; then compound 2; then compounds 4 and 3 (each within the scatter of the next).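

Within the data shown here, changing the saturated chain carbon and the saturated ring carbon together gives a 1.2-fold lower number from compound 3 to compound 4 (0.07 log units; within the scatter) and is the only step here that alters configuration alone, so the two drawn forms are not separated on this read-out: the fact that compounds 3 and 4 differ only in the configuration as drawn.

Fluoro in place of hydrogen still gives a step beyond the scatter with the other drawn form, a 2.3-fold higher number from compound 2 to compound 4 (0.36 log units; beyond the scatter) in this case. Against tert-butyl, 1-(fluoromethyl)ethyl likewise gives a 5.3-fold higher number from compound 1 to compound 4 (0.72 log units; beyond the scatter) as a step beyond the scatter.

From the compounds shown here alone, what each stereocentre does alone stays open, since both change together. Also open, going by these compounds, is how trifluoromethyl or a longer chain in place of fluoromethyl would read.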